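The compounds below may be only part of what the source reports. "The series", "measured", "known", "first", "only" and "open" are said of these compounds alone.

Measured so far in an ADME assay on microsomes from liver (Mus musculus) for metabolic stability, read by LC-MS, using NADPH, with a stated time of 10 min, tested at 0.1 uM; a lower number here means slower removal, a higher number faster removal of the compound
- compound 1 `Cc1cccc(N2C(=O)CSC2c2cccc(C(=O)NCCCCc3ccccc3)c2)c1` gives 2940 mL.min-1.g-1
- compound 2 `O=C(NCCCCn1cccn1)c1cccc(C2SCC(=O)N2c2ccccn2)c1` gives 304 mL.min-1.g-1
- compound 3 `Cc1ccnc(N2C(=O)CSC2c2cccc(C(=O)NCCCCn3cccn3)c2)c1` gives 392 mL.min-1.g-1

Compound 2 sits at the low end of this small set together with compound 3, and the number for compound 1 stands well above it, beyond the scatter. Compound 4 `O=C(NCCCCc1ccccc1)c1cccc(C2SCC(=O)N2c2ccccn2)c1` is the next compound to read against compound 2. The change is phenyl in place of 1H-pyrazol-1-yl on a saturated chain carbon, four bonds along the chain from an amide-type nitrogen and it can also be read as 3-(1H-pyrazol-1-yl)propyl to 3-phenylpropyl.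

For the measured compounds named here, the only measured step, a 1.3-fold higher number from compound 2 to compound 3 (0.11 log units; within the scatter), is methyl in place of hydrogen on an aromatic carbon. It is a different change at a different place, so it gives no size for this one. Going by the values given here, the closest evidence is compound 1 at 2940 mL.min-1.g-1 as the only measured compound with the phenyl end group. It also differs from compound 4 elsewhere in the structure, so the data do not show how much of its high number goes with the phenyl. A rise is therefore expected, but only part of the gap to compound 1. In this assay the estimated step is a 3.9-fold higher number from compound 2 to compound 4 (0.60 log units; beyond the scatter) and it is expected to lie beyond the scatter. The estimate for compound 4 is 1200 mL.min-1.g-1 with an expected range from 500 mL.min-1.g-1 to 2800 mL.min-1.g-1 as the working figure.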

Compound 4, intrinsic clearance in microsomes: 644 mL.min-1.g-1
Compound 4: the middle estimate sits 1.9-fold (0.27 log units) above what was measured, within the range that was stated.
By their numbers in this assay, from the lowest: compounds 2, 3 and 4 (each within the scatter of the next, the first and the last beyond it); then compound 1.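

In this assay, phenyl in place of 1H-pyrazol-1-yl on a saturated chain carbon, four bonds along the chain from an amide-type nitrogen, gives a 2.1-fold higher number from compound 2 to compound 4 (0.33 log units; beyond the scatter) with the rest of the structure held constant, so this change now has a measured size of its own, modest but beyond the scatter. With the phenyl held constant, pyridin-2-yl in place of 3-methylphenyl on an amide-type nitrogen in a ring gives a 4.6-fold lower number from compound 1 to compound 4 (0.66 log units; beyond the scatter) in the same read-out, which shows that the high number of compound 1 does not go with the phenyl alone. No measurement at hand gives a reason for either step.

Still open, as far as these compounds go, is whether the phenyl for 1H-pyrazol-1-yl change has a similar size when 3-methylphenyl rather than pyridin-2-yl sits on the amide-type nitrogen in a ring. Also open is how a tertiary amine, a carboxylic acid or a shorter chain would read at this position in this assay against the two end groups shown here.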